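This account rests on a few compounds, and the source may have more. Where it says the series, first, only, none or still open, it means among the compounds named here.

Compound 3 `COc1ccccc1Oc1ccc2c(NCCCNCc3cccc(OC)c3O)ccnc2c1` gives 14500 nM in a physicochemical assay for solubility, with a stated time of 18 h, at pH 7.4 (on this read-out higher numbers stand for higher solubility and lower numbers for lower solubility), the second highest of the three numbers measured. Compound 1 `COc1cccc(CNCCCNc2ccnc3cc(-c4ccc(F)cc4)ccc23)c1O` gives 32000 nM, and compound 2 `COc1cccc(CNCCCNc2ccnc3cc(Cc4cc(C)cc(C)c4)ccc23)c1O` gives 4200 nM. The two measured steps that reach compound 3 are a 2.2-fold lower number from compound 1 to compound 3 (0.34 log units; beyond the scatter) and a 3.5-fold higher number from compound 2 to compound 3 (0.54 log units; beyond the scatter). Compound 4 `COc1cccc(CNCCCNc2ccnc3cc(C4CCCCC4)ccc23)c1O` differs from compound 3 in one place: cyclohexyl in place of 2-methoxyphenoxy on an aromatic carbon. The entering cyclohexyl carries no hydrogen-bond acceptors and no aromatic ring, which makes it closer in kind to the 3,5-dimethylbenzyl of compound 2 than to the group it replaces, so the step from compound 2 to compound 3 is the one that bears most here, and running it in reverse points to a modest drop. The expected step is a 2.6-fold lower number from compound 3 to compound 4 (0.42 log units; beyond the scatter). Compound 4 is therefore estimated at 5500 nM, with a likely range from 2000 nM to 15000 nM.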

Compound 4, solubility: 4200 nM
Compound 4: the middle estimate sits 1.3-fold (0.12 log units) above what was measured; measured number inside the range.
By their numbers in this assay, from the lowest: compounds 2 and 4 (each within the scatter of the next); then compound 3; then compound 1.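

The step of no change at the digits printed from compound 2 to compound 4 (within the scatter) appears when cyclohexyl replaces 3,5-dimethylbenzyl, so in this assay an aromatic ring on this carbon does not by itself separate these two groups. Against the other two groups, cyclohexyl gives a 3.5-fold lower number from compound 3 to compound 4 (0.54 log units; beyond the scatter) and a 7.6-fold lower number from compound 1 to compound 4 (0.88 log units; beyond the scatter) at this same place. The four compounds therefore split into a lower pair, compounds 2 and 4, and the higher compounds 3 and 1.

Going by these compounds, whether a morpholine or a carboxylic acid on this carbon would join the lower pair stays open. Nothing given here explains the split.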